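The compounds below may be only part of what the source reports. "The series", "measured", "known", "first", "only" and "open" are said of these compounds alone.

Four compounds share one core and differ only in the group attached through the sulfur-bound chain carbon. Compound 1 `C#CCNC1CCc2c(SCc3ccc(Br)cc3)cccc21` carries a 4-bromophenyl there, and in an ADME assay on isolated protein for inhibition of Amine oxidase [flavin-containing] B (Homo sapiens) (a higher number here means a weaker inhibitor, a lower number a stronger inhibitor), compound 1 gives 488 nM. Compound 2 `C#CCNC1CCc2c(SCc3ccc(C(F)(F)F)cc3)cccc21` differs from it by trifluoromethyl in place of bromo on an aromatic carbon, and in this assay compound 2 gives 930 nM; the step of a 1.9-fold higher number from compound 1 to compound 2 (0.28 log units; within the scatter) is small. Compound 3 `C#CCNC1CCc2c(SCc3cccc(Br)c3)cccc21` keeps the same atoms as compound 1 but joined differently: 3-bromophenyl in place of 4-bromophenyl on a saturated chain carbon bound to a sulfur. For compound 3, this assay reports only a limit, > 100000 nM, so no number is known for it. The step of an at least 200-fold higher number from compound 1 to compound 3 (2.31 log units; beyond the scatter) is therefore at least very large, and compound 3 sits at the limit of > 100000 nM in this assay, at which 1 of the 3 values shown sits.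

Compound 4 `C#CCNC1CCc2c(SCc3cccc(C(F)(F)F)c3)cccc21` has not yet been measured. It relates to compound 3 as compound 2 relates to compound 1: trifluoromethyl in place of bromo on an aromatic carbon. Among the compounds with values here, this is the same kind of change as the one from compound 1 to compound 2, though the surroundings differ: in compound 2 the new group stands para to a large group, in compound 4 it stands meta to a large group. Since that earlier exchange moved the number only by a 1.9-fold higher number from compound 1 to compound 2 (0.28 log units; within the scatter), which lies within the scatter, the step from compound 3 to compound 4 is expected to be similarly small, a step that the limit leaves unreadable from compound 3 to compound 4. Compound 4 is thus estimated at 150000 nM in this assay, with a good chance that only a limit is reported again.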

Compound 4, half-maximal inhibitory concentration: 7710 nM
For compound 4 the middle estimate is 19-fold (1.29 log units) above the measured one; the measured number lies below the stated range.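

The exchange of bromo for trifluoromethyl on an aromatic carbon does not keep its size when carried from the core of compound 1 to the core of compound 3: the same change on two cores in this assay, a 1.9-fold higher number (0.28 log units; within the scatter) from compound 1 to compound 2 and an at least 12-fold lower number (1.11 log units; beyond the scatter) from compound 3 to compound 4, at least 24-fold (1.39 log units) apart, beyond the scatter of two such steps

In this assay, the new pair shows this exchange as an at least 12-fold lower number from compound 3 to compound 4 (1.11 log units; beyond the scatter), a large change, whereas the same exchange made almost no difference in the earlier pair. Compound 3 gives > 100000 nM, which is a limit of the assay and not a number, so the size of the new step is known only as a bound, and these two pairs do not show why the exchange behaves differently or how it would behave on any further core.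

Going by these compounds, it remains open whether other groups on the same aromatic carbon, such as chloro, methoxy or nitrile, would leave the number almost unchanged, as in the step to compound 2, or shift it strongly, as in the step to compound 4. Also open, on these data alone, is what a plain phenyl without any such group would give on the saturated chain carbon bound to the sulfur.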